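A few compounds are considered here, and "the series" means these few. Any claim that something is new, unique, unknown or untested is made for them only; others in the source may bear on it.

The series shares one core, seen in compound 1 `CCC1(Cc2ccccc2)OS(=O)(=O)C=C1OCC#N`, compound 2 `CCC1(Cc2ccccc2)OS(=O)(=O)C=C1OC` and compound 3 `CCC1(Cc2ccccc2)OS(=O)(=O)C=C1OCC1CCCCC1`, and differs only in the group on the double-bonded ring carbon. In an ADME assay on HEL cells (Homo sapiens) for cytotoxicity, with a stated time of 3 days (on this read-out lower numbers stand for higher toxicity in this test and higher numbers for lower toxicity in this test), compound 1 gives > 400000 nM, which is a limit of the assay and not a number. Compound 2 likewise gives > 400000 nM in this assay, again a limit rather than a number. Compound 3 stands at >= 200000 nM in this assay, also a limit. The three steps among these compounds, a step that the two limits leave unreadable from compound 1 to compound 2, a step that the two limits leave unreadable from compound 1 to compound 3 and a step that the two limits leave unreadable from compound 2 to compound 3, therefore carry no readable size; the whole picture is set by the limit of > 400000 nM in this assay, at which 2 of the 3 values shown sit, and (the limit of >= 200000 nM in this assay, at which 1 of the 3 values shown sits). Compound 4 `CCC1(Cc2ccccc2)OS(=O)(=O)C=C1NCc1ccccc1` differs from compound 3 by benzylamino in place of cyclohexylmethoxy on a double-bonded ring carbon. Among the compounds with values here, none of the measured steps can be read, so none of them gives a size that bears on this change; all that the numbers show is that every value so far sits at a limit of this assay. For compound 4 in this assay a step that the limit leaves unreadable from compound 3 to compound 4 is expected, meaning no move that the scatter would not cover. The value of compound 4 is estimated at 300000 nM, within a range from 100000 nM to 500000 nM.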

Compound 4, minimum cytotoxic concentration: >= 80000 nM
Compound 4: no number, only a limit; the forecaster's own chance of this, stated with the estimate: 80%; the middle value does not contradict the limit.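

In this assay compound 4 gives >= 80000 nM, a limit of the assay and not a number, so its steps to compound 1, compound 2 and compound 3 cannot be read. The compounds shown leave open whether benzylamino in place of cyclohexylmethoxy on the double-bonded ring carbon shifts this read-out at all, and by how much.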